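This account rests on a few compounds, and the source may have more. Where it says the series, first, only, none or still open, it means among the compounds named here.

Measured compounds:
- Compound 1 `O=C1O[C@@H](CO)CN1c1ccc(-n2cc(-c3ccccn3)cn2)c(F)c1` in an ADME assay on HEK293-A cells (Homo sapiens) for cytotoxicity, read by MTT assay, with a stated time of 48 h (a higher number here means a weaker inhibitor, a lower number a stronger inhibitor), gives > 400 ug/mL, which is a limit of the assay and not a number.
- Compound 2 `CCN1CCN(C[C@H]2CN(c3ccc(-n4cc(-c5ccccn5)cn4)c(F)c3)C(=O)O2)CC1` in this assay gives 99 ug/mL.
- Compound 3 `O=C1O[C@@H](CN2CCCCC2)CN1c1ccc(-n2cc(-c3ccccn3)cn2)c(F)c1` in this assay gives > 400 ug/mL, again a limit of the assay and not a number.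

Compound 3 therefore stands at the limit at which two of the three values sit (the limit of > 400 ug/mL in this assay, at which 2 of the 3 values shown sit). Compound 4 `O=CNC[C@H]1CN(c2ccc(-n3cc(-c4ccccn4)cn3)c(F)c2)C(=O)O1` differs from compound 3 in one place: formylamino in place of piperidin-1-yl on a saturated chain carbon bound to a saturated ring carbon. The step that the two limits leave unreadable from compound 1 to compound 3 cannot be read, and the step of an at least 4.0-fold higher number from compound 2 to compound 3 (0.60 log units; beyond the scatter) shows that exchanging one saturated ring for another moved the number beyond the scatter. The step of an at least 4.0-fold lower number from compound 1 to compound 2 (0.60 log units; beyond the scatter) shows that a small hydroxy and the larger 4-ethylpiperazin-1-yl sit apart as well. Formylamino, like hydroxy, is small and carries a hydrogen-bond donor, so compound 4 is expected to stay at the limit rather than move toward compound 2, and the expected step of a number no higher from compound 3 to compound 4 (the limit leaves the size open) is none beyond the scatter. Compound 4 is estimated at 400 ug/mL, within 200 ug/mL to 800 ug/mL.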

Compound 4, half-maximal inhibitory concentration: > 400 ug/mL
Compound 4: only a limit was reported; the forecaster's own chance of this, stated with the estimate: 75%; the middle value sits exactly at the limit.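

In this assay, formylamino at this place, on a saturated chain carbon bound to a saturated ring carbon, gives a limit and not a number, so the steps among compound 1, compound 3 and compound 4 cannot be read. Against compound 2, the change gives an at least 4.0-fold higher number from compound 2 to compound 4 (0.60 log units; beyond the scatter), so 4-ethylpiperazin-1-yl now stands apart from a third group, this one without a ring. Compound 2 remains the only compound shown with a number and not a limit, and the share of values at the limit has grown: the limit of > 400 ug/mL in this assay, at which 3 of the 4 values shown sit.

From the compounds shown here alone, the true numbers behind the limits of compound 1, compound 3 and compound 4 stay unknown. Also open, going by these compounds, is whether a number like that of compound 2 would appear with another group at this place, such as piperazin-1-yl without the ethyl group, or a carboxylic acid.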